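A few compounds are considered here, and "the series" means these few. Any claim that something is new, unique, unknown or untested is made for them only; others in the source may bear on it.

Compound 1, `CCCc1nc(C(C)(C)O)c(C(=O)NCCCCCC[N+](=O)[O-])n1Cc1ccc(-c2ccccc2C2=NNNN2)cc1`: 101%
Compound 2, `CCCCCCCCOC(=O)c1c(C(C)(C)O)nc(CCC)n1Cc1ccc(-c2ccccc2C2=NNNN2)cc1`: 90.2%
Compound 3, `CCCc1nc(C(C)(C)O)c(C(=O)OCCCCCC[N+](=O)[O-])n1Cc1ccc(-c2ccccc2C2=NNNN2)cc1`: 100%

All three compounds share one core and were run in an ADME assay on a cell-free system (plasma, Rattus norvegicus, strain Sprague-Dawley) for metabolic stability, with a stated time of 30 min, tested at 50 mg/mL; on this read-out higher numbers stand for a more stable compound and lower numbers for a less stable compound. Compound 3 stands second highest of the three numbers shown. Its nearest neighbour is compound 1, and the step of a number 1 percentage points lower from compound 1 to compound 3 (within the scatter) lies within the scatter of the method. Its furthest neighbour is compound 2, yet even the step of a number 9.8 percentage points higher from compound 2 to compound 3 (within the scatter) stays within that scatter. Among the compounds with values here, the only step that went beyond the scatter is a number 10.8 percentage points lower from compound 1 to compound 2 (beyond the scatter), a modest drop.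

Compound 4, `CCCc1nc(C(C)(C)O)c(C(=O)OCCCCCCC(=O)O)n1Cc1ccc(-c2ccccc2C2=NNNN2)cc1`, differs from compound 3 in one place: carboxy in place of nitro on a saturated chain carbon, six bonds along the chain from an oxygen next to a carbonyl group. Within the data shown here, no measured step swaps a nitro for a carboxy, so none bears on this change directly. Among the measured compounds shown here, the closest precedent is the step from compound 2 to compound 3, an exchange at the same chain position that stayed within the scatter, and all three measured compounds sit close together and high on this read-out. On that basis the change is expected to leave the number where compound 3 already is, with no step beyond the scatter. The expected step is a number 3 percentage points lower from compound 3 to compound 4 (within the scatter). Compound 4 is therefore estimated at 97%, within a range from 86% to 105%.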

Compound 4, percent of the compound remaining: 98.8%
Estimate against measurement, compound 4: 1.8 percentage points below, within the range that was stated.
By their numbers in this assay, from the lowest: compounds 2, 4, 3 and 1 (each within the scatter of the next, the first and the last beyond it).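

At the chain carbon six bonds along from an oxygen next to a carbonyl group, carboxy in place of nitro gives a number 1.2 percentage points lower from compound 3 to compound 4 (within the scatter) in this assay, so this position now holds a nitro and a carboxy end group that the read-out does not separate. Set against the octyloxy compound, the carboxy end gives a number 8.6 percentage points higher from compound 2 to compound 4 (within the scatter), which means that compound 4, like compound 3, cannot be told apart from compound 2 at this position, although the step from compound 1 to compound 2 went beyond the scatter. Exchanging the whole substituent on the carbonyl carbon, (6-carboxyhexyl)oxy in place of (6-nitrohexyl)amino, gives a number 2.2 percentage points lower from compound 1 to compound 4 (within the scatter), so the carboxy-ended chain on its oxygen link also sits with the amide-linked nitro chain on this read-out.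

The compounds shown leave open whether an amine at the same chain carbon, a longer chain ending in carboxy, or a (6-carboxyhexyl)amino group on the carbonyl carbon would stay equally close in this assay. Nothing in the available data accounts for these numbers.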